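Adding a bromo group to compound 1

The compounds below may be only part of what the source reports. "The series", "measured", "known", "first", "only" and "open" are said of these compounds alone.

Measured in a functional assay on ECa-109 cells for antiproliferative activity against ECa-109 cell line (Homo sapiens), read by MTT assay, with a stated time of 72 h (a lower number here means a stronger inhibitor, a higher number a weaker inhibitor), so far:
compound 1 `O=C(N/N=C/c1ccccc1O)c1cccc(S(=O)(=O)N2CCOCC2)c1` gives 14400 nM
compound 2 `CCN(CC)c1ccc(/C=N/NC(=O)c2cccc(S(=O)(=O)N3CCOCC3)c2)c(O)c1` gives 730 nM

Compound 1 holds the higher of these two numbers, which makes it the weaker inhibitor of the pair. Compound 3 `O=C(N/N=C/c1cc(Br)ccc1O)c1cccc(S(=O)(=O)N2CCOCC2)c1` is not yet measured. It differs from compound 1 in one place: bromo in place of hydrogen on an aromatic carbon, so that 2-hydroxyphenyl becomes 5-bromo-2-hydroxyphenyl.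

Among the compounds with values here, only one measured step bears on this change, a 20-fold lower number from compound 1 to compound 2 (1.30 log units; beyond the scatter) with diethylamino in place of hydrogen on an aromatic carbon. That step is large, but it is a single case and involves a different group. A lower number is therefore expected in this assay but by a smaller margin. The estimated step is a 2.9-fold lower number from compound 1 to compound 3 (0.46 log units; beyond the scatter) in size. Compound 3 is expected at 5000 nM (1500 nM to 16000 nM).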

Compound 3, half-maximal inhibitory concentration: 11700 nM
Beside the measured number, compound 3's estimate is 2.3-fold (0.37 log units) below it; the measured number falls inside the stated range.
By their numbers in this assay, from the lowest: compound 2; then compounds 3 and 1 (each within the scatter of the next).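

In this assay the bromo group, on an aromatic carbon para to a hydroxy group, gives a 1.2-fold lower number from compound 1 to compound 3 (0.09 log units; within the scatter) and so brings no real change in this read-out. Set against a 20-fold lower number from compound 1 to compound 2 (1.30 log units; beyond the scatter) on the same 2-hydroxyphenyl ring, this shows that the large step seen with diethylamino does not extend to every group placed on this ring: 5-bromo-2-hydroxyphenyl performs like plain 2-hydroxyphenyl here. No measurement is available that would explain why the two groups differ so much.

The compounds shown leave open whether another amine, such as dimethylamino or a ring amine like morpholine, would keep the step seen with diethylamino. They also leave open whether a methoxy group or a chloro group on this ring would behave more like diethylamino or like bromo.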